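Terminal hydroxy on the ether chain of compound 3

A few compounds are considered here, and "the series" means these few. Any claim that something is new, unique, unknown or untested is made for them only; others in the source may bear on it.

Values in an assay on membranes from lung (Cavia porcellus) for binding affinity to cysteinyl leukotriene receptor (Homo sapiens); a higher number here means a weaker inhibitor, a lower number a stronger inhibitor:
compound 1 `CCCCCCCCCCCCc1ccccc1C(SCCC(=O)O)SCCC(=O)O`: 445 nM
compound 2 `CCCCCCCCCCC#Cc1ccccc1C(SCCC(=O)O)SCCC(=O)O`: 2520 nM
compound 3 `CCCCCCCCCOc1ccccc1C(SCCC(=O)O)SCCC(=O)O`: 4090 nM

Compound 3 carries the highest number of the three. Compound 2 sits within the scatter of it, so no order between these two can be read; compound 1 lies beyond the scatter with a lower number, and is the one that stands apart here.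

Compound 4 `O=C(O)CCSC(SCCC(=O)O)c1ccccc1OCCCCCCCCCO` differs from compound 3 by hydroxy in place of hydrogen on a saturated chain carbon, nine bonds along the chain from an oxygen on an aromatic ring. Going by the values given here, no measured pair in this set shows that change, so its size is unknown. The expectation is no step beyond the scatter, with a slight lean toward a higher number in this assay, expressed as a 1.3-fold higher number from compound 3 to compound 4 (0.13 log units; within the scatter). For compound 4 the estimated value is 5500 nM, expected to fall between 2000 nM and 16000 nM.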

Compound 4, inhibition constant: > 20000 nM
Compound 4: a limit, no number; the forecaster's own chance of this, stated with the estimate: 10%; middle value at least 3.6-fold (0.56 log units) away from the limit.
By their numbers in this assay, from the lowest: compound 1; then compounds 2 and 3 (each within the scatter of the next). At a limit, above all of these: compound 4.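

In this assay the chain end of compound 3 proves sensitive to a single change, with hydroxy in place of hydrogen giving an at least 4.8-fold higher number from compound 3 to compound 4 (0.68 log units; beyond the scatter) on an otherwise unchanged structure. Compound 4 gives > 20000 nM, a limit and not a number, so this first step read in one place in the series has no measured size. Only its lower bound is available: the limit of > 20000 nM in this assay, at which 1 of the 4 values shown sits.

Open, as far as these compounds go, is whether an amine or a carboxylic acid at the same chain end would give a step of similar size. Also open, from the compounds shown here alone, is whether hydroxy at the end of the chain of compound 1 would repeat this step.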